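The source may hold more compounds than are shown below. What is called first, only, known or untested is meant among the compounds shown, and "the series" means these compounds.

Compound 1, `Cn1c(=O)c(=O)n(C2CCCC2)c2nc(N/N=C/c3ccc(C(F)(F)F)cc3)ncc21`, is assessed in a functional assay on HCT-116 cells (Homo sapiens) for antiproliferative activity, read by MTT assay (a higher number here means a weaker inhibitor, a lower number a stronger inhibitor), where compound 1 gives 29000 nM. Among the three compounds measured in this assay, compound 1 stands second highest. Its nearest neighbour is compound 2, `COc1ccc(/C=N/Nc2ncc3c(n2)n(C2CCCC2)c(=O)c(=O)n3C)cc1`, which in this assay gives 36100 nM; the gap from compound 1 to compound 2 is a 1.2-fold higher number from compound 1 to compound 2 (0.10 log units; within the scatter), a change of methoxy in place of trifluoromethyl on an aromatic carbon that leaves the two values indistinguishable. Within the data shown here, the furthest is compound 3, `Cn1c(=O)c(=O)n(C2CCCC2)c2nc(N/N=C/c3cc(C(F)(F)F)cc(C(F)(F)F)c3)ncc21`, which in this assay gives 4360 nM; no single-point step connects it to compound 1, so the two values can only be placed side by side.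

Compound 4, `Cn1c(=O)c(=O)n(C2CCCC2)c2nc(N/N=C/c3cccc([N+](=O)[O-])c3)ncc21`, has not yet been measured. The change from compound 1 is 3-nitrophenyl in place of 4-(trifluoromethyl)phenyl on a carbon with a double bond to nitrogen. Among the measured compounds shown here, no measured step touches a nitro group, and the one step that exchanges the substituent on that aryl ring, the step from compound 1 to compound 2, falls within the scatter. On that basis the step from compound 1 to compound 4 in this assay is expected to be a 1.5-fold lower number from compound 1 to compound 4 (0.16 log units; within the scatter), with no clear direction beyond the scatter. Compound 4 is therefore estimated at 20000 nM in this assay, within a range from 7000 nM to 60000 nM.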

Compound 4, half-maximal inhibitory concentration: 15200 nM
Estimate against measurement, compound 4: 1.3-fold (0.12 log units) above; low and high end bracket the measured number.
By their numbers in this assay, from the lowest: compound 3; then compounds 4, 1 and 2 (each within the scatter of the next, the first and the last beyond it).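

At the carbon with a double bond to nitrogen, exchanging the aryl group now gives its first step beyond the scatter in this assay: 3-nitrophenyl in place of 4-methoxyphenyl gives a 2.4-fold lower number from compound 2 to compound 4 (0.38 log units; beyond the scatter), a modest change, whereas 3-nitrophenyl in place of 4-(trifluoromethyl)phenyl gives a 1.9-fold lower number from compound 1 to compound 4 (0.28 log units; within the scatter), which cannot be told from no change. The aryl group at this place therefore has some bearing on the read-out, but the effect depends on which pair is compared, as compound 1 stays within the scatter of both compound 2 and compound 4 while those two separate. Nothing available accounts for this modest separation or says what lies behind it.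

Both new steps alter the substituent and its place on the ring together, so the compounds shown cannot separate the nitro group from its 3-position, and a 4-nitrophenyl partner would be needed to do so. Also open is how an amine or a carboxylic acid on this aryl ring would read in this assay, since the compounds shown carry neither group.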